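From butoxy to (furan-2-yl)oxy on a shared core

The source may hold more compounds than are shown below. What is called first, only, known or untested is meant among the compounds shown, and "the series" means these compounds.

Compound 1 (`CCCCOC1=CC(=O)c2ccccc2C1=O`) gives 35300 nM in a functional assay on HeLa cells (Homo sapiens) for cytotoxicity; on this read-out lower numbers stand for stronger inhibition and higher numbers for weaker inhibition. For the measured compounds named here, the only other measured compound, compound 2 (`O=C(Oc1ccc2c(c1)C(=O)C=CC2=O)c1ccccc1`), gives 19200 nM in this assay, and the two values lie within the scatter of each other. Compound 1 therefore stands level with compound 2 on the numbers available.

Compound 3 (`O=C1C=C(Oc2ccco2)C(=O)c2ccccc21`) has not yet been measured. It departs from compound 1 in one place: furan-2-yl in place of butyl on an oxygen on an unsaturated carbon. In short, furan-2-yl takes the place of butyl on an oxygen on an unsaturated carbon, which reads as butoxy to (furan-2-yl)oxy.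

Going by the values given here, no measured pair shows what this exchange does, so the expectation rests on two values alone. With compound 1 at 35300 nM and compound 2 at 19200 nM, no large step is expected in this assay, only a small move toward a lower number that may stay within the scatter. The expected change is a 1.6-fold lower number from compound 1 to compound 3 (0.21 log units; within the scatter). For compound 3 the estimated value is 22000 nM, with an expected range from 7000 nM to 60000 nM.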

Compound 3, half-maximal inhibitory concentration: 37000 nM
Estimate against measurement, compound 3: 1.7-fold (0.23 log units) below; the measured number falls inside the stated range.
By their numbers in this assay, from the lowest: compounds 2, 1 and 3 (each within the scatter of the next).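

In this assay, for the compounds shown here, the exchange of butyl for furan-2-yl on an oxygen on an unsaturated carbon gives a 1.0-fold higher number from compound 1 to compound 3 (0.02 log units; within the scatter) and so provides the first measured pair that differs in one place. At this position, therefore, an open chain with no ring and a five-membered aromatic ring with one hetero atom give values within the scatter of each other, even though furan-2-yl adds a ring and a hydrogen-bond acceptor that butyl does not have. Nothing in the data at hand accounts for this result.

One exchange cannot show whether this position is generally insensitive to the group on the oxygen, since an amine-bearing chain, a carboxylic acid, a phenyl ring or a longer chain could behave differently from butyl and furan-2-yl. From the compounds shown here alone, it also remains open whether any group at this position can move the number beyond the scatter in this assay and whether the same exchange would read alike on another core.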